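A few compounds are considered here, and "the series" means these few. Any claim that something is new, unique, unknown or untested is made for them only; others in the source may bear on it.

Measured compounds in a functional assay for antagonist activity at 5-hydroxytryptamine receptor 4 (Cavia porcellus); on this read-out higher numbers stand for higher potency (the scale is a negative logarithm) and lower numbers for lower potency:
compound 1 `CN1CCN(CCNC(=O)n2c(=O)n(Cc3ccccc3)c3ccccc32)CC1` — < 6
compound 2 `CC(C)n1c(=O)n(C(=O)NCCN2CCN(C)CC2)c2ccccc21` — < 6
compound 3 `C=CCn1c(=O)n(C(=O)NCCN2CCN(C)CC2)c2ccccc21` — < 6

Each of these three values is a limit of this assay and not a number. Compound 2 stands only at such a limit; no reading of its own is known. Compound 4 `CC(C)n1c(=O)n(C(=O)NCCN2CCN(C)CC2)c2cc(Cl)ccc21` differs from compound 2 by chloro in place of hydrogen on an aromatic carbon. The measured steps touching compound 2 are a step that the two limits leave unreadable from compound 1 to compound 2 and a step that the two limits leave unreadable from compound 2 to compound 3; neither can be read, since every value sits at the limit of < 6 in this assay, at which 3 of the 3 values shown sit. For the measured compounds named here, no measured step therefore gives a direction for the chloro change, and the step that the limit leaves unreadable from compound 2 to compound 4 is an estimate resting on the shared limit alone. Compound 4 is expected near 5.7, between 5 and 6.5, and is most likely reported again only as a limit.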

Compound 4, negative logarithm of the antagonist equilibrium constant: < 6
Compound 4 ended at the assay's limit; the forecaster's own chance of this, stated with the estimate: 70%; the middle value lies beyond the limit too.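

The step from compound 2 to compound 4 cannot be read, as both stand only at a limit: the limit of < 6 in this assay, at which 4 of the 4 values shown sit.

Going by these compounds, whether chloro in place of hydrogen on an aromatic carbon shifts potency in this assay stays open, as does any ranking among the four compounds.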